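The compounds below may be only part of what the source reports. "The series", "measured", "known", "first", "only" and "open" are said of these compounds alone.

Measured so far:
- compound 1 `Cc1cc(N2CC[C@@H](C)[C@@H](N(C)c3ncnc4[nH]ccc34)C2)n2nc(SCC3CCCCC3)nc2n1`: 98200 nM
- compound 2 `CCCCCc1c(C)nc2nc(SCc3ccc(Cl)cc3)nn2c1N1CC[C@@H](C)[C@@H](N(C)c2ncnc3[nH]ccc23)C1`: > 100000 nM (a limit)
- compound 3 `CCc1cc(N2CC[C@@H](C)[C@@H](N(C)c3ncnc4[nH]ccc34)C2)n2ncnc2n1`: > 100000 nM (a limit)

Within the data shown here, in a toxicity assay on GES1 cells (Homo sapiens) for inhibition, read by MTT assay, with a stated time of 72 h (a lower number here means a stronger inhibitor, a higher number a weaker inhibitor), compound 1 gives 98200 nM, the only actual number. Compound 2 and compound 3 are limits of the assay, not numbers: the limit of > 100000 nM in this assay, at which 2 of the 3 values shown sit.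

Next is compound 4 `Cc1cc(N2CC[C@@H](C)[C@@H](N(C)c3ncnc4[nH]ccc34)C2)n2nc(SCc3ccc([N+](=O)[O-])cc3)nc2n1`, which has 4-nitrophenyl in place of cyclohexyl on a saturated chain carbon bound to a sulfur. Among the measured compounds shown here, no measured pair isolates this change, so the expectation rests on compound 1 at 98200 nM. No step beyond the scatter is expected in this assay, in either direction. The estimated step runs a 1.2-fold lower number from compound 1 to compound 4 (0.06 log units; within the scatter). Compound 4 is estimated at 85000 nM, with an expected range of 35000 nM to 100000 nM.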

Compound 4, half-maximal inhibitory concentration: 36600 nM
Estimate against measurement, compound 4: 2.3-fold (0.37 log units) above; low and high end bracket the measured number.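

In this assay, the group on a saturated chain carbon bound to a sulfur can move the read-out: 4-nitrophenyl in place of cyclohexyl gives a 2.7-fold lower number from compound 1 to compound 4 (0.43 log units; beyond the scatter). Among these compounds, this is the only step that can be read, and it is modest, though beyond the scatter. Much of the series still stands at a limit of the assay: the limit of > 100000 nM in this assay, at which 2 of the 4 values shown sit.

This one pair changes the aromatic ring and the nitro group together and does not separate them. From the compounds shown here alone, how a plain phenyl or a 4-aminophenyl would read at this place remains open.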